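Replacing formyl in the series

The compounds below may be only part of what the source reports. "The series", "measured", "known", "first", "only" and "open" are said of these compounds alone.

Compound 2 `CN(C)c1nc(NCc2ccc(NC(=O)c3ccc(F)cc3)cc2)c2ccc(C=O)cc2n1` stands lowest of the two measured numbers in a physicochemical assay for solubility, at pH 7.4; on this read-out lower numbers stand for lower solubility and higher numbers for higher solubility: compound 2 gives 1 ug/mL, while compound 1 `CC(O)c1ccc2c(NCc3ccc(NC(=O)c4ccc(F)cc4)cc3)nc(N(C)C)nc2c1` gives 18 ug/mL. Compound 3 `CN(C)Cc1ccc2c(NCc3ccc(NC(=O)c4ccc(F)cc4)cc3)nc(N(C)C)nc2c1` carries (dimethylamino)methyl in place of formyl on an aromatic carbon. Within the data shown here, one measured step bears on this, an 18-fold lower number from compound 1 to compound 2 (1.26 log units; beyond the scatter), which is large and beyond the scatter and ends at the same formyl compound. It involves a different group, so the support is thin. An upward step is expected in this assay, a 15-fold higher number from compound 2 to compound 3 (1.18 log units; beyond the scatter). For compound 3 the estimate is 15 ug/mL, with an expected range of 3 ug/mL to 80 ug/mL.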

Compound 3, solubility: 55 ug/mL
Compound 3: middle estimate off by 3.7-fold (0.56 log units), on the low side, and the stated range covers the measured number.
By their numbers in this assay, from the lowest: compound 2; then compound 1; then compound 3.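

With (dimethylamino)methyl on this aromatic carbon, this assay shows a 55-fold higher number from compound 2 to compound 3 (1.74 log units; beyond the scatter) against formyl and a 3.1-fold higher number from compound 1 to compound 3 (0.49 log units; beyond the scatter) against 1-hydroxyethyl. Compound 3 is therefore highest of the three, and the rise at this position extends past the level of 1-hydroxyethyl, not only past formyl. Nothing available explains this order of the three groups.

Open, on these data alone, is whether the gain stays with a primary aminomethyl, a morpholinylmethyl or a longer aminoethyl chain at this carbon. Also open, as far as these compounds go, is how a carboxylic acid here would compare with compound 3.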